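The source may hold more compounds than are shown below. What is called first, only, known or untested is meant among the compounds shown, and "the series" means these compounds.

Compound 3 `O=C(CN1CCN(c2ccccc2)CC1)N1CCN(c2nnc(-c3ccc(Cl)cc3)c(-c3ccc(Cl)cc3)n2)CC1` is one of three analogues built on a shared core and tested in an ADME assay on NIH3T3 cells (Mus musculus) for cytotoxicity, read by MTT assay, with a stated time of 24 h; a lower number here means a stronger inhibitor, a higher number a weaker inhibitor. Compound 1 `COc1cccc(N2CCN(CC(=O)N3CCN(c4nnc(-c5ccccc5)c(-c5ccccc5)n4)CC3)CC2)c1` gives 361000 nM in this assay. Compound 2 `Cc1ccc(-c2nnc(N3CCN(C(=O)CN4CCN(c5cccc(Cl)c5)CC4)CC3)nc2-c2ccc(C)cc2)cc1` gives 859000 nM in this assay. For compound 3 this assay returns only a limit, > 850000 nM, so its place among the three is known only as a bound (the limit of > 850000 nM in this assay, at which 1 of the 3 values shown sits). No pair of these compounds differs in a single place, so no measured step is available.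

Compound 4 `COc1ccc(N2CCN(CC(=O)N3CCN(c4nnc(-c5ccc(Cl)cc5)c(-c5ccc(Cl)cc5)n4)CC3)CC2)cc1` differs from compound 3 by a methoxy in place of hydrogen on an aromatic carbon. With compound 3 known only as a limit, the expected step from compound 3 to compound 4 in this assay cannot be sized beyond the scatter in either direction, and the estimate an at least 1.2-fold lower number from compound 3 to compound 4 (0.08 log units; that floor lies within the scatter) is therefore placed close to where compound 3 already sits. Compound 4 is expected to give about 700000 nM in this assay, within a range from 300000 nM to 2000000 nM, with a fair chance that only a limit is reported.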

Compound 4, half-maximal inhibitory concentration: > 809000 nM
Compound 4 was reported as a limit; the forecaster's own chance of this, stated with the estimate: 50%; middle value at least 1.1-fold (0.06 log units) from the limit.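

In this assay, among the compounds shown here, compound 3 and compound 4 are both reported only as limits, so no step between them can be read. The compounds shown leave open whether phenyl to 4-methoxyphenyl changes the half-maximal inhibitory concentration at all, and in which direction.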